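This account rests on a few compounds, and the source may have more. Where it says the series, first, only, none or still open, it means among the compounds named here.

Compound 3 `CC(C)C[C@H](N)c1cc(C(F)(F)F)ccc1N1CCN(C(=O)[C@H]2CCO[C@@H]2c2ccc(Cl)cc2)CC1` gives 330 nM in an assay on HEK293 cells for displacement of a labelled ligand from Melanocortin receptor 4 (Homo sapiens); a lower number here means a stronger inhibitor, a higher number a weaker inhibitor. Its two measured companions differ from it only in the ring attached to the carbonyl: compound 1 `CC(C)C[C@H](N)c1cc(C(F)(F)F)ccc1N1CCN(C(=O)[C@H]2CSC[C@@H]2c2ccc(Cl)cc2)CC1` gives 280 nM, and compound 2 `CC(C)C[C@H](N)c1cc(C(F)(F)F)ccc1N1CCN(C(=O)C2COCC2c2ccc(Cl)cc2)CC1` gives 280 nM, and the steps of a 1.2-fold higher number from compound 1 to compound 3 (0.07 log units; within the scatter) and a 1.2-fold higher number from compound 2 to compound 3 (0.07 log units; within the scatter) both stay within the scatter. Compound 4 `CC(C)C[C@H](N)c1cc(Cl)ccc1N1CCN(C(=O)[C@H]2CCO[C@@H]2c2ccc(Cl)cc2)CC1` is compound 3 with chloro in place of trifluoromethyl on an aromatic carbon. For the measured compounds named here, none of the three measured steps touches this ring, so no measured step bears on the change; the expectation rests only on the observation that the shared core has so far given numbers that are alike. Compound 4 is therefore expected to give 330 nM in this assay, with a range from 110 nM to 1000 nM. The step of no change at the digits printed from compound 3 to compound 4 (within the scatter) that this estimate means is expected to stay within the scatter.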

Compound 4, inhibition constant: 280 nM
For compound 4 the middle estimate is 1.2-fold (0.07 log units) above the measured one; the range from low to high includes it.
By their numbers in this assay, from the lowest: compounds 1, 2, 4 and 3 (each within the scatter of the next).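

Chloro in place of trifluoromethyl, on the aromatic carbon para to a large group, gives a 1.2-fold lower number from compound 3 to compound 4 (0.07 log units; within the scatter) in this assay. For the compounds shown here, the earlier compounds differed only in the ring on the carbonyl, so this is the first sign that this position, too, can take a change of group with the two numbers remaining alike. No measurement at hand accounts for this result.

Going by these compounds, whether a nitrile, an amine or a methoxy group here would also stay within the scatter remains open. So does whether this swap behaves alike with the 4-(4-chlorophenyl)thiolan-3-yl group of compound 1.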